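Swapping the phenyl of compound 3

This account rests on a few compounds, and the source may have more. Where it says the series, first, only, none or still open, it means among the compounds named here.

Measured in an ADME assay on PA-1 cells (Homo sapiens) for cytotoxicity, read by MTT assay, with a stated time of 72 h; a lower number here means a stronger inhibitor, a higher number a weaker inhibitor:
- Compound 1 `COc1ccc(OC)c(C2=C(c3cc(OC)c(OC)c(OC)c3)C(=O)CC2O[SiH2]C(C)(C)C)c1`: 17 ug/mL
- Compound 2 `COc1ccc(C2=C(c3cc(OC)c(OC)c(OC)c3)C(=O)CC2O)cc1O`: < 1 ug/mL (a limit)
- Compound 3 `COc1cc(C2=C(c3ccccc3)C(O[SiH2]C(C)(C)C)CC2=O)cc(OC)c1OC`: > 100 ug/mL (a limit)

Compound 3 gives only a limit, > 100 ug/mL, so no true number marks its place. Compound 4 `COc1ccc(C2=C(c3cc(OC)c(OC)c(OC)c3)C(=O)CC2O[SiH2]C(C)(C)C)cc1O` differs from it by 3-hydroxy-4-methoxyphenyl in place of phenyl on a double-bonded ring carbon. Among the compounds with values here, the one measured step at this place is an at least 5.8-fold higher number from compound 1 to compound 3 (0.76 log units; beyond the scatter), where the number rose as phenyl came in, and it too rests on a limit. Compound 2 also carries 3-hydroxy-4-methoxyphenyl and gives a limit, < 1 ug/mL. Removing phenyl should therefore lower the number in this assay clearly, towards compound 1 at 17 ug/mL. The expected step is an at least 10-fold lower number from compound 3 to compound 4 (1.00 log units; beyond the scatter). For compound 4 the estimate is 10 ug/mL, with an expected range from 2 ug/mL to 45 ug/mL.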

Compound 4, half-maximal inhibitory concentration: 14 ug/mL
Beside the measured number, compound 4's estimate is 1.4-fold (0.15 log units) below it, within the range that was stated.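

In this assay, replacing plain phenyl with 3-hydroxy-4-methoxyphenyl gives an at least 7.1-fold lower number from compound 3 to compound 4 (0.85 log units; beyond the scatter), a step that rests on a limit. Set against 2,5-dimethoxyphenyl, the same group gives a 1.2-fold lower number from compound 1 to compound 4 (0.08 log units; within the scatter), so these two groups cannot be told apart here. On the oxygen elsewhere in the core, the group of 5 heavy atoms gives an at least 14-fold higher number from compound 2 to compound 4 (1.14 log units; beyond the scatter), also resting on a limit, so 3-hydroxy-4-methoxyphenyl alone does not fix the number.

On these data alone, how a phenyl carrying an amine or a carboxylic acid would compare stays open. Also open, as far as these compounds go, is how far apart the compounds with limits truly lie.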